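The compounds below may be only part of what the source reports. "The series", "measured", "known", "first", "only" and "open" are said of these compounds alone.

In a functional assay on MCF7 cells (Homo sapiens) for cytotoxicity, read by sulforhodamine B assay, with a stated time of 48 h (a higher number here means a weaker inhibitor, a lower number a stronger inhibitor), compound 3 `Nc1c(-c2nc3ccccc3[nH]2)cc(-c2ccccc2)n1-c1cccc(Br)c1` gives 2120 nM as the highest number of the three measured, while compound 2 `Nc1c(-c2nc3ccccc3[nH]2)cc(-c2ccccc2)n1-c1ccncc1` stands at 705 nM in the same series. Compound 4 `Nc1c(-c2nc3ccccc3[nH]2)cc(-c2ccccc2)n1Cc1nc2ccccc2[nH]1` differs from compound 3 by (1H-benzimidazol-2-yl)methyl in place of 3-bromophenyl on an aromatic nitrogen. Going by the values given here, the only measured step at this nitrogen is a 3.0-fold higher number from compound 2 to compound 3 (0.48 log units; beyond the scatter) for 3-bromophenyl in place of pyridin-4-yl, modest but beyond the scatter. Compound 1 `N#Cc1cc(-c2ccccc2)n(Cc2nc3ccccc3[nH]2)c1N` already carries (1H-benzimidazol-2-yl)methyl there and gives 515 nM with a nitrile in place of the 1H-benzimidazol-2-yl group. A modest fall is therefore expected in this assay as the estimated 2.8-fold lower number from compound 3 to compound 4 (0.45 log units; beyond the scatter) for this change. For compound 4 the estimated value is 750 nM within an expected range (250 nM to 2200 nM).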

Compound 4, half-maximal inhibitory concentration: 972 nM
Compound 4: middle estimate off by 1.3-fold (0.11 log units), on the low side; low and high end bracket the measured number.
By their numbers in this assay, from the lowest: compounds 1, 2 and 4 (each within the scatter of the next); then compound 3.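

In this assay, the (1H-benzimidazol-2-yl)methyl group on the aromatic nitrogen separates from 3-bromophenyl (a 2.2-fold lower number from compound 3 to compound 4 (0.34 log units; beyond the scatter)) but not from pyridin-4-yl (a 1.4-fold higher number from compound 2 to compound 4 (0.14 log units; within the scatter)). With (1H-benzimidazol-2-yl)methyl on that nitrogen, replacing cyano with 1H-benzimidazol-2-yl on the aromatic carbon also stays within the scatter (a 1.9-fold higher number from compound 1 to compound 4 (0.28 log units; within the scatter)). No measurement offered here explains these differences. The compounds shown leave open how a longer chain ending in an amine or a carboxylic acid on the aromatic nitrogen would fare.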